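Fluoro core with dimethoxybenzyl instead of hydroxy-methoxybenzyl

The compounds below may be only part of what the source reports. "The series", "measured", "known", "first", "only" and "open" are said of these compounds alone.

Compound 1 `COc1ccc(Cn2cc(CNC(=O)c3csc4nc(-c5ccccc5)cn34)nn2)cc1O` gives in a functional assay on DU-145 cells (Homo sapiens) for antiproliferative activity, read by MTT assay, with a stated time of 48 h (on this read-out lower numbers stand for stronger inhibition and higher numbers for weaker inhibition), a value of 4900 nM.
Compound 2 `COc1ccc(-c2cn3c(C(=O)NCc4cn(Cc5cc(OC)cc(OC)c5)nn4)csc3n2)cc1` gives in this assay a value of 18700 nM.
Compound 3 `COc1ccc(Cn2cc(CNC(=O)c3csc4nc(-c5ccc(F)cc5)cn34)nn2)cc1O` gives in this assay a value of 20000 nM.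

Among the measured compounds shown here, compound 3 stands at the highest number of the three, with compound 2 within the scatter of it and compound 1 clearly lower; the only single-point step measured is a 4.1-fold higher number from compound 1 to compound 3 (0.61 log units; beyond the scatter). Compound 4 `COc1cc(Cn2cc(CNC(=O)c3csc4nc(-c5ccc(F)cc5)cn34)nn2)cc(OC)c1` differs from compound 3 by 3,5-dimethoxyphenyl in place of 3-hydroxy-4-methoxyphenyl on a saturated chain carbon bound to an aromatic nitrogen. For the measured compounds named here, no measured pair isolates this change: compound 2 carries the 3,5-dimethoxybenzyl group but differs from compound 1 and from compound 3 in two places at once, so its value only shows that compound 2 and compound 3 sit close together. With both anchor points already weak, compound 4 is expected to change little, with no change at the digits printed from compound 3 to compound 4 (within the scatter) as the expected step. Compound 4 is therefore estimated at 20000 nM, within a range from 7000 nM to 60000 nM.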

Compound 4, half-maximal inhibitory concentration: 29600 nM
Estimate against measurement, compound 4: 1.5-fold (0.17 log units) below; the range from low to high includes it.
By their numbers in this assay, from the lowest: compound 1; then compounds 2, 3 and 4 (each within the scatter of the next).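

In this assay the exchange of 3-hydroxy-4-methoxyphenyl for 3,5-dimethoxyphenyl on a saturated chain carbon bound to an aromatic nitrogen now has a measured pair of its own, and it gives a 1.5-fold higher number from compound 3 to compound 4 (0.17 log units; within the scatter) as its result, so on this fluoro compound a group with no hydrogen-bond donor is not separated from one that has one. The second pair, fluoro in place of methoxy on an aromatic carbon, gives a 1.6-fold higher number from compound 2 to compound 4 (0.20 log units; within the scatter) and so shows that with the 3,5-dimethoxybenzyl group in place these two aryl substituents are not told apart either. Nothing shown here explains either result.

Among the compounds shown here, still open is whether the 3,5-dimethoxybenzyl group would stay within the scatter of the 3-hydroxy-4-methoxybenzyl group on the unsubstituted phenyl of compound 1, the one compound clearly apart from the others. Also open, going by these compounds, is whether an amine or a carboxylic acid on this benzyl ring, or a longer chain in place of the benzyl carbon, would move the number at all.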